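The compounds below may be only part of what the source reports. "The series", "measured", "known", "first", "only" and "open" are said of these compounds alone.

Measured in a functional assay on U-937 cells (Homo sapiens) for antiproliferative activity, read by MTT assay, with a stated time of 24 h; on this read-out lower numbers stand for stronger inhibition and higher numbers for weaker inhibition:
- compound 1 `CCCCNC(=O)COc1ccc(C(=O)c2c(CCCC)oc3ccccc23)cc1` gives 22800 nM
- compound 2 `CCCCc1oc2ccccc2c1C(=O)c1ccc(OCC(=O)N[C@H](C)c2ccccc2)cc1` gives 19800 nM
- compound 3 `CCCCc1oc2ccccc2c1C(=O)c1ccc(OCCCC(=O)N2CCOCC2)cc1` gives 21400 nM

Compound 3 stands level with the other two, with no order among the three values: a 1.1-fold lower number from compound 1 to compound 3 (0.03 log units; within the scatter) and a 1.1-fold higher number from compound 2 to compound 3 (0.03 log units; within the scatter) are both within the scatter.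

The next change leads to compound 4 `CCCCc1oc2ccccc2c1C(=O)c1ccc(OCCCC(=O)N[C@H](C)c2ccccc2)cc1` and reads ((1-phenylethyl)amino in place of morpholin-4-yl on a carbonyl carbon), in words (1-phenylethyl)amino in place of morpholin-4-yl on a carbonyl carbon.

The closest evidence is a 1.1-fold higher number from compound 2 to compound 3 (0.03 log units; within the scatter), where the same two amide groups differ, together with a 1.2-fold lower number from compound 1 to compound 2 (0.06 log units; within the scatter), where 1-phenylethyl enters on an amide-type nitrogen. Both are within the scatter, so no step beyond the scatter is expected in this assay.

The expected step is a 1.1-fold lower number from compound 3 to compound 4 (0.03 log units; within the scatter).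

The estimate for compound 4 is 20000 nM, with a range from 11000 nM to 36000 nM.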

Compound 4, half-maximal inhibitory concentration: 30700 nM
Compound 4: middle estimate off by 1.5-fold (0.19 log units), on the low side; the measured number falls inside the stated range.
By their numbers in this assay, from the lowest: compounds 2, 3, 1 and 4 (each within the scatter of the next).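

In this assay, with the carbonyl carbon bound to a saturated chain carbon, (1-phenylethyl)amino in place of morpholin-4-yl gives a 1.4-fold higher number from compound 3 to compound 4 (0.16 log units; within the scatter). This position therefore shows no step beyond the scatter, even though an aromatic ring, a hydrogen-bond donor and a defined stereocentre enter with the new group and the six-membered non-aromatic ring leaves. No measured property bears on this result.

Open, as far as these compounds go, is whether a carboxylic acid or a piperazin-1-yl amide on this carbonyl carbon would give a step beyond the scatter.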